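Shortening the Hydroxamate Chain on a Shared Core

The source may hold more compounds than are shown below. What is called first, only, known or untested is meant among the compounds shown, and "the series" means these compounds.

Compound 1 `Nc1nc2cc(-c3nn(CCCCCC(=O)NO)c4ncnc(N)c34)ccc2o1`: 37600 nM
Compound 2 `Nc1nc2cc(-c3nn(CCCCCCCCCC(=O)NO)c4ncnc(N)c34)ccc2o1`: 36800 nM

Compound 1 and compound 2 share one core and differ only in the length of the chain that carries the hydroxycarbamoyl group. In a functional assay on CNE-2 cells (Homo sapiens) for inhibition, read by MTT assay, with a stated time of 72 h (on this read-out higher numbers stand for weaker inhibition and lower numbers for stronger inhibition), compound 1 gives 37600 nM and compound 2 gives 36800 nM. Going by the values given here, the step of a 1.0-fold lower number from compound 1 to compound 2 (0.01 log units; within the scatter) shows that lengthening this chain left the number within the scatter, so compound 2 and compound 1 sit at the same level on the numbers so far.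

Compound 3 `Nc1nc2cc(-c3nn(CCCC(=O)NO)c4ncnc(N)c34)ccc2o1` has not yet been measured in this assay. It differs from compound 2 by hydroxycarbamoyl in place of 6-(hydroxycarbamoyl)hexyl on a saturated chain carbon, three bonds along the chain from an aromatic nitrogen. Among the compounds with values here, the only measured step that bears on this change, a 1.0-fold lower number from compound 1 to compound 2 (0.01 log units; within the scatter), also altered only the chain length and stayed within the scatter, so no step beyond the scatter is expected here either. For compound 3 the expected step is a 1.1-fold higher number from compound 2 to compound 3 (0.04 log units; within the scatter). Compound 3 is therefore expected to give about 40000 nM in this assay, with a range from 15000 nM to 110000 nM.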

Compound 3, half-maximal inhibitory concentration: > 50000 nM
Compound 3 gave a limit, no number; the forecaster's own chance of this, stated with the estimate: 15%; middle value at least 1.2-fold (0.09 log units) from the limit.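

For compound 3 the read-out gives a limit and not a number: the limit of > 50000 nM in this assay, at which 1 of the 3 values shown sits. Against the two longer chains this means an at least 1.3-fold higher number from compound 2 to compound 3 (0.13 log units; that floor lies within the scatter) and an at least 1.3-fold higher number from compound 1 to compound 3 (0.12 log units; that floor lies within the scatter), and both are only floors, so the true gaps could be larger or could stay small. Compounds 1 and 2 sat level, which made chain length look unimportant at this position, but compound 3 weakens that reading without overturning it, since what can be stated with certainty still lies within the scatter.

The compounds shown leave open how far compound 3 really lies from the other two, and whether a chain longer than the one in compound 2 would keep the same level. They also leave open what a carboxylic acid or a primary amide would do in place of the hydroxycarbamoyl group at the chain end.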